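Shifting the amide aryl from dimethyl to difluoro

The source may report more compounds than this note shows. Statements on the series, on what has been measured and on what is new or still open speak of the compounds shown alone.

Compound 2 `Cc1cc(C)cc(C(=O)Nc2cccc(-c3oc4cc(-c5ccc(F)cc5)ccc4c(=O)c3O)c2)c1` carries a 3,5-dimethylphenyl on the carbonyl carbon of the amide. In a functional assay on HCC1937 cells (Homo sapiens) for antiproliferative activity, read by CCK-8 assay, with a stated time of 72 h (a lower number here means a stronger inhibitor, a higher number a weaker inhibitor), compound 2 gives 4860 nM, the lowest of the two numbers recorded, with its nearest neighbour compound 1 `O=C(Nc1cccc(-c2oc3cc(-c4ccc(F)cc4)ccc3c(=O)c2O)c1)c1cccc(F)c1`, which in this assay gives 6590 nM. Within the data shown here, the only measured step, a 1.4-fold lower number from compound 1 to compound 2 (0.13 log units; within the scatter), lies within the scatter. Compound 3 `O=C(Nc1cccc(-c2oc3cc(-c4ccc(F)cc4)ccc3c(=O)c2O)c1)c1cc(F)cc(F)c1` differs from compound 2 in one place: 3,5-difluorophenyl in place of 3,5-dimethylphenyl on a carbonyl carbon. That step bears on the earlier one, since both swap substituents on the same aryl ring of the amide, and that earlier swap moved the number little. Compound 3 is therefore expected to land close to compound 1 and compound 2, with a step of a 1.2-fold higher number from compound 2 to compound 3 (0.09 log units; within the scatter), not beyond the scatter. For compound 3 the estimate in this assay is 6000 nM, ranging from 2500 nM to 15000 nM.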

Compound 3, half-maximal inhibitory concentration: 2070 nM
The estimate for compound 3 lay 2.9-fold (0.46 log units) above the measured number; measured number outside the range, below it.
By their numbers in this assay, from the lowest: compound 3; then compounds 2 and 1 (each within the scatter of the next).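

At this position on the carbonyl carbon of the amide, the aryl substituents can move the number beyond the scatter, which the earlier swap had not shown. In this assay, 3,5-difluorophenyl in place of 3,5-dimethylphenyl gives a 2.3-fold lower number from compound 2 to compound 3 (0.37 log units; beyond the scatter), and fluoro in place of hydrogen on an aromatic carbon of the 3-fluorophenyl ring gives a 3.2-fold lower number from compound 1 to compound 3 (0.50 log units; beyond the scatter), both modest steps. Nothing available here accounts for the lower number of compound 3.

From the compounds shown here alone, whether the number falls further with other groups on this ring remains open, for example with 3,5-dichlorophenyl or with a ring bearing an amine or a carboxylic acid. Also open, going by these compounds, is how the number would respond if a longer chain replaced the aryl ring on the carbonyl carbon.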